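The source may report more compounds than this note shows. Statements on the series, on what has been measured and on what is new or still open speak of the compounds shown alone.

Within the data shown here, in an assay on HEK293 cells for displacement of a labelled ligand from Type-2 angiotensin II receptor (Homo sapiens), read by scintillation counting, with a stated time of 240 min (on this read-out higher numbers stand for weaker inhibition and lower numbers for stronger inhibition), compound 1 `COC(=O)NS(=O)(=O)c1sc(CC(C)C)cc1-c1cccc(Cn2ccnc2)c1` gives 400 nM, the highest of the three numbers measured so far, though only by a little. Compound 2 `CCOC(=O)NS(=O)(=O)c1sc(CC(C)C)cc1-c1cccc(Cn2ccnc2)c1` gives 300 nM, and compound 3 `CC(C)Cc1cc(-c2cccc(Cn3ccnc3)c2)c(S(=O)(=O)NC(=O)OC(C)(C)C)s1` gives 270 nM. The steps of a 1.3-fold lower number from compound 1 to compound 2 (0.12 log units; within the scatter), a 1.5-fold lower number from compound 1 to compound 3 (0.17 log units; within the scatter) and a 1.1-fold lower number from compound 2 to compound 3 (0.05 log units; within the scatter) all stay within the scatter: changing the group on an oxygen next to a carbonyl group has so far left the numbers essentially unchanged. Compound 4 `COCCOC(=O)NS(=O)(=O)c1sc(CC(C)C)cc1-c1cccc(Cn2ccnc2)c1` has not yet been measured in this assay. It differs from compound 1 by methoxymethyl in place of hydrogen on a saturated chain carbon bound to an oxygen next to a carbonyl group. Since every measured change at this position was small, no step beyond the scatter is expected here either. Compound 4 is therefore estimated to give 330 nM, with a range from 150 nM to 750 nM. The expected step is a 1.2-fold lower number from compound 1 to compound 4 (0.08 log units; within the scatter).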

Compound 4, inhibition constant: 480 nM
For compound 4 the middle estimate is 1.5-fold (0.16 log units) below the measured one; low and high end bracket the measured number.
By their numbers in this assay, from the lowest: compounds 3, 2, 1 and 4 (each within the scatter of the next).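

A methoxy group on the chain, in the 2-methoxyethyl group, still does not move the number beyond the scatter: a 1.2-fold higher number from compound 1 to compound 4 (0.08 log units; within the scatter), a 1.6-fold higher number from compound 2 to compound 4 (0.20 log units; within the scatter) and a 1.8-fold higher number from compound 3 to compound 4 (0.25 log units; within the scatter). Methyl, ethyl, tert-butyl and 2-methoxyethyl on the oxygen next to the carbonyl group therefore cannot be told apart in this assay. No measurement shown speaks to why the numbers stay so close. On these data alone, whether an amine, a carboxylic acid or a longer chain at this position would produce a step beyond the scatter remains open.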